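Swapping methoxy for chloro on a weak sulfonamide

This account rests on a few compounds, and the source may have more. Where it says the series, first, only, none or still open, it means among the compounds named here.

Of the compounds shown here, three built on a shared indole-amine core have been measured in a functional assay on MCF7 cells (Homo sapiens) for antiproliferative activity, read by MTT assay, with a stated time of 24 h; on this read-out lower numbers stand for stronger inhibition and higher numbers for weaker inhibition. Going by the values given here, compound 1 `O=C(Nc1ccc2cc[nH]c2c1)c1ccc(Br)cc1` gives 38100 nM, and compound 3 `O=C(Nc1ccc2cc[nH]c2c1)c1ccc(F)cc1` gives 45900 nM; the one step between them, a 1.2-fold higher number from compound 1 to compound 3 (0.08 log units; within the scatter), is a swap of one halogen for another that leaves the read-out essentially unmoved. Compound 2 `COc1ccc(S(=O)(=O)Nc2ccc3cc[nH]c3c2)cc1` is the only sulfonamide among them and gives 57200 nM; its number sits at the upper edge of the three, yet the gaps to compound 1 and compound 3 are both within the scatter, so nothing separates it from the two amides.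

Compound 4 `O=S(=O)(Nc1ccc2cc[nH]c2c1)c1ccc(Cl)cc1` is the next sulfonamide in this assay. It differs from compound 2 in one place: chloro in place of methoxy on an aromatic carbon. Among the compounds with values here, no measured step bears directly on this change, since the only step available, from compound 1 to compound 3, trades one halogen for another on the amide series. The whole set lies in a narrow band, so compound 4 is expected to remain near compound 2, with a step of a 1.1-fold lower number from compound 2 to compound 4 (0.06 log units; within the scatter) that stays within the scatter. Compound 4 is therefore estimated at 50000 nM, expected to lie between 20000 nM and 125000 nM.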

Compound 4, half-maximal inhibitory concentration: 54000 nM
Compound 4: the middle estimate sits 1.1-fold (0.03 log units) below what was measured, within the range that was stated.
By their numbers in this assay, from the lowest: compounds 1, 3, 4 and 2 (each within the scatter of the next).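

In this assay, the change from methoxy to chloro on an aromatic carbon para to a large group gives a 1.1-fold lower number from compound 2 to compound 4 (0.03 log units; within the scatter) and so does not separate the two groups on the sulfonamide. The earlier compounds shown here offered only a 1.2-fold higher number from compound 1 to compound 3 (0.08 log units; within the scatter), a swap of one halogen for another on the amides; here a group that is not a halogen leaves, taking its oxygen and its hydrogen-bond acceptor with it, and the read-out still shows no change beyond the scatter. The position has now been varied in both series without a step that can be told from repeat measurement, although no independent measurement is available to say what lies behind this result.

The compounds shown leave open whether this position responds at all to groups of a different kind, such as an amine, a carboxylic acid or a longer chain, on either the sulfonamide or the amide. They also leave open how an amide carrying chloro or methoxy at this position would compare with compound 4 or compound 2, a comparison that would isolate the link itself.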